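Lengthening the Alkyl Chain from Pentyl to Hexyl

A few compounds are considered here, and "the series" means these few. Any claim that something is new, unique, unknown or untested is made for them only; others in the source may bear on it.

Compound 1 `CCCCOc1ccc(Nc2nc3nonc3nc2O)cc1` gives 3700 nM in an assay on mitochondria from L6 cells (Rattus norvegicus) for activation, with a stated time of 90 min; on this read-out higher numbers stand for an effect only at larger amounts of compound and lower numbers for an effect already at smaller amounts.
Compound 2 `CCc1ccc(Nc2nc3nonc3nc2O)cc1` gives 10700 nM in this assay.
Compound 3 `CCCCCc1ccc(Nc2nc3nonc3nc2O)cc1` gives 2400 nM in this assay.

Compound 3 has the lowest number of the three. Its nearest neighbour is compound 1, and that gap lies within the usual scatter, so the two cannot be ranked against each other; compound 2 stands furthest away, beyond the scatter. Compound 4 `CCCCCCc1ccc(Nc2nc3nonc3nc2O)cc1` differs from compound 3 in one place: methyl in place of hydrogen on a saturated chain carbon, five bonds along the chain from an aromatic carbon. The step that bears most directly on this is the chain growth from compound 2 to compound 3, which gave a 4.5-fold lower number from compound 2 to compound 3 (0.65 log units; beyond the scatter). The step of a 1.5-fold lower number from compound 1 to compound 3 (0.19 log units; within the scatter), by contrast, lies within the scatter. Adding a single methyl is a smaller change than adding propyl, so only a small further lowering, or none beyond the scatter, is expected in this assay. Compound 4 is therefore estimated at 1600 nM, with a range from 600 nM to 4000 nM. This estimate means an expected step of a 1.5-fold lower number from compound 3 to compound 4 (0.18 log units; within the scatter).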

Compound 4, half-maximal effective concentration: 4700 nM
Beside the measured number, compound 4's estimate is 2.9-fold (0.47 log units) below it; measured number outside the range, above it.
By their numbers in this assay, from the lowest: compounds 3, 1 and 4 (each within the scatter of the next); then compound 2.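

Going from pentyl to hexyl gives a 2.0-fold higher number from compound 3 to compound 4 (0.29 log units; within the scatter) in this assay, so the methyl added five bonds along the chain from an aromatic carbon brings no readable change at this end of the chain. Measured against the ethyl of compound 2, hexyl still gives a 2.3-fold lower number from compound 2 to compound 4 (0.36 log units; beyond the scatter), so the modest lowering seen with the longer chain remains at hexyl, while the growth from pentyl to hexyl adds nothing that can be read. Hexyl also cannot be told apart from butoxy, with a 1.3-fold higher number from compound 1 to compound 4 (0.10 log units; within the scatter) in this assay, so among these three groups, butoxy, pentyl and hexyl, no order can be given.

Nothing at hand explains why these numbers fall as they do. Still open, going by these compounds, is how a longer chain such as octyl, or a carboxylic acid in place of the chain, would read in this assay.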